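This account rests on a few compounds, and the source may have more. Where it says the series, first, only, none or still open, it means among the compounds named here.

Measured so far:
- compound 1, `CC1CCN(c2c(S(=O)(=O)c3cccc(C#N)c3)cnc3cc(F)ccc23)CC1`, 92% in an assay on isolated protein for displacement of a labelled ligand from metabotropic glutamate receptor 5 (Homo sapiens), with a stated time of 60 min, tested at 1 uM; on this read-out higher numbers stand for more inhibition at the one concentration tested (going by the name of the read-out) and lower numbers for less inhibition
- compound 2, `CC1CCN(c2c(S(=O)(=O)c3cccc(C#N)c3)cnc3cc(Cl)ccc23)CC1`, 94% in this assay
- compound 3, `COCC1CCN(c2c(S(=O)(=O)c3cccc(C#N)c3)cnc3cc(F)ccc23)CC1`, 91% in this assay

Compound 1 stands second highest of the three numbers, but all three sit close together: the step of a number 2 percentage points higher from compound 1 to compound 2 (within the scatter) and the step of a number 1 percentage points lower from compound 1 to compound 3 (within the scatter) are both within the scatter, so no ordering among compounds 1, 2 and 3 can be read from this assay. Those two steps change the substituent on the core of compound 1 and the substituent on the saturated ring, not the aryl group on the sulfonyl sulfur.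

Compound 4, `CC1CCN(c2c(S(=O)(=O)c3cc(F)cc(F)c3)cnc3cc(F)ccc23)CC1`, is not yet measured. It differs from compound 1 as follows: 3,5-difluorophenyl in place of 3-cyanophenyl on a sulfonyl sulfur. Neither measured step bears on this part of the molecule, so there is no direct guide to the size of the change in this assay. What the three measured compounds do show is that the core of compound 1 with a 3-cyanophenyl on the sulfonyl sulfur gives high inhibition whatever is varied elsewhere. Compound 4 keeps that core and the saturated ring of compound 1, so the expectation is a small step, a number 8 percentage points lower from compound 1 to compound 4 (within the scatter), with widened uncertainty because the sulfonyl aryl has not been varied before. The estimate for compound 4 in this assay is 84%, within 62% to 96%.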

Compound 4, a percentage reported as inhibition, at one concentration (the size of the read-out at that concentration, not a potency): 77%
For compound 4 the middle estimate is 7 percentage points above the measured one, within the range that was stated.
By their numbers in this assay, from the lowest: compound 4; then compounds 3, 1 and 2 (each within the scatter of the next).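

In this assay the aryl group on the sulfonyl sulfur is the only one of the three varied places where a single change moves the number beyond the scatter: 3,5-difluorophenyl in place of 3-cyanophenyl gives a number 15 percentage points lower from compound 1 to compound 4 (beyond the scatter). The high numbers of compounds 1, 2 and 3 therefore do not hold whatever is changed, as all three carry the 3-cyanophenyl, and the core alone does not keep compound 4 level with them. The change removes the nitrile and brings in two fluorines in one move, and no measurement at hand connects the lower number to either part of it or offers any explanation for it.

Still open, as far as these compounds go, is where a plain phenyl or a 3-fluorophenyl on the sulfonyl sulfur would fall relative to compound 1 and compound 4, which would help separate the loss of the nitrile from the gain of the fluorines. Also open, from the compounds shown here alone, is whether the step keeps its size with the chloro substituent of compound 2 or the methoxy-bearing saturated ring of compound 3, as the 3,5-difluorophenyl appears here only in compound 4.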